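The source may hold more compounds than are shown below. What is called first, only, known or untested is meant among the compounds shown, and "the series" means these compounds.

Compound 2, `CCC1=C(N2CC2)C(=O)C(C(COC(N)=O)OC)=C(N2CC2)C1=O`, is the reference point of this small set. In a functional assay on L1210 cells (Mus musculus), with a stated time of 12 days (a lower number here means a less potent compound, a higher number a more potent compound, by a factor of ten per unit of this negative logarithm), compound 2 gives 6.16, the highest of the three numbers in hand. Compound 1, `CCCC1=C(N2CC2)C(=O)C(C(COC(N)=O)OC)=C(N2CC2)C1=O`, carries one more carbon on the chain and gives 5.63; the step of a number 0.53 log units higher from compound 1 to compound 2 (beyond the scatter) is modest but beyond the scatter. Compound 3, `CCOC(COC(N)=O)C1=C(N2CC2)C(=O)C(CC)=C(N2CC2)C1=O`, carries a methyl on the ether-bearing carbon and gives 5.76; the step of a number 0.40 log units lower from compound 2 to compound 3 (beyond the scatter) is likewise modest and beyond the scatter.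

Compound 4, `CCC1=C(N2CC2)C(=O)C(CC)=C(N2CC2)C1=O`, has not yet been measured. Compared with compound 2 it shows (a group of 2 heavy atoms (2 carbon; no ring) in place of a group of 8 heavy atoms (4 carbon, 1 nitrogen, 3 oxygen; no ring), on a double-bonded ring carbon). Neither measured step bears directly on this change: the step from compound 1 to compound 2 alters the alkyl chain, the step from compound 2 to compound 3 alters the ether end of the side chain, and both were modest. Removing the whole side chain is a larger change than either, so a step in this assay is expected that could exceed either of those, and the loss of the carbamate group makes a decrease the more likely direction. Compound 4 is therefore expected to give 5.8, between 5.2 and 6.4, a step of a number 0.36 log units lower from compound 2 to compound 4 (beyond the scatter).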

Compound 4, logarithm of the reciprocal of the active concentration, log(1/C): 5.46
Compound 4: the middle estimate sits 0.34 log units above what was measured; low and high end bracket the measured number.
By their numbers in this assay, from the lowest: compounds 4, 1 and 3 (each within the scatter of the next); then compound 2.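

In this assay, among these compounds, the earlier steps only altered parts of the molecule, whereas here the whole group of 8 heavy atoms on the double-bonded ring carbon gives way to ethyl, and the result is a number 0.70 log units lower from compound 2 to compound 4 (beyond the scatter). This shows that the group at this position counts for something in this read-out, since compound 2 stands beyond the scatter of the plain ethyl analogue. It also shows that the group is not needed for activity as such, as compound 4, with ethyl in its place, still gives 5.46. No measurement on hand explains why the number falls with this exchange.

The compounds shown leave open which part of the departed group accounts for the difference, the ether oxygen with its small alkyl group or the far end of the side chain, since every compound but compound 4 keeps that side chain whole. They also do not tell whether a simple hydroxymethyl, an aminomethyl or a carboxylic acid on this ring carbon would give a number closer to that of compound 2 or to that of compound 4.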